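A few compounds are considered here, and "the series" means these few. Any claim that something is new, unique, unknown or untested is made for them only; others in the source may bear on it.

Working notes on the series.

Compound 1, `COc1ccc(-c2nn(-c3ccccc3)cc2/C=C/C(=O)c2ccc(OCc3ccccc3)c3c2OC(C)(C)C3)cc1`, is the reference point. In a functional assay on PC-3 cells (Homo sapiens) for antiproliferative activity, read by MTT assay, with a stated time of 48 h (a higher number here means a weaker inhibitor, a lower number a stronger inhibitor), compound 1 gives 7900 nM. Compound 2, `Cc1ccc(-c2nn(-c3ccccc3)cc2/C=C/C(=O)c2ccc(OCc3ccccc3)c3c2OC(C)(C)C3)cc1`, carries methyl in place of methoxy on an aromatic carbon, the change (methyl in place of methoxy on an aromatic carbon). In this assay compound 2 gives only a limit, > 100000 nM, and no number. The step is an at least 12-fold higher number from compound 1 to compound 2 (1.10 log units; beyond the scatter), with the result resting at the limit of > 100000 nM in this assay, at which 1 of the 3 values shown sits.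

Compound 3, `COc1ccc(-c2nn(-c3ccccc3)cc2/C=C/C(=O)c2ccc3c(c2OCc2ccccc2)CC(C)(C)O3)cc1`, has the same atoms as compound 1 joined differently; the difference between the two cores is not broken down here. In this assay compound 3 gives 18400 nM, a higher number than compound 1.

Compound 4, `Cc1ccc(-c2nn(-c3ccccc3)cc2/C=C/C(=O)c2ccc3c(c2OCc2ccccc2)CC(C)(C)O3)cc1`, carries the change (methyl in place of methoxy on an aromatic carbon), the same change as from compound 1 to compound 2, at the same kind of place, para to a large group. The expected step is an 8.2-fold higher number from compound 3 to compound 4 (0.91 log units; beyond the scatter). This expectation rests on the earlier step, an at least 12-fold higher number from compound 1 to compound 2 (1.10 log units; beyond the scatter), and on compound 3 already standing at 18400 nM. Compound 4 is therefore expected at about 150000 nM, most likely reported only as a limit, with an estimated span from 40000 nM to 600000 nM.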

Compound 4, half-maximal inhibitory concentration: 24200 nM
Estimate against measurement, compound 4: 6.2-fold (0.79 log units) above, outside the stated range (below it).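

In this assay, the change from 4-methoxyphenyl to 4-methylphenyl does not carry over from one core to the other with the same size: the same change on two cores in this assay, an at least 12-fold higher number (1.10 log units; beyond the scatter) from compound 1 to compound 2 and a 1.3-fold higher number (0.12 log units; within the scatter) from compound 3 to compound 4, at least 9.6-fold (0.98 log units) apart, beyond the scatter of two such steps. The new step is a 1.3-fold higher number from compound 3 to compound 4 (0.12 log units; within the scatter), so on the core of compound 3 this change leaves no readable difference. Going by these compounds, compound 2 is a limit and not a number, so the full size of the earlier step stays unknown, and two pairs show neither why the two cores respond differently nor how a third core would respond: the limit of > 100000 nM in this assay, at which 1 of the 4 values shown sits.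

Open, on these data alone, is whether the two cores also part ways for other groups at this place on the ring, such as a hydroxyl, a chlorine atom or an amine, and whether a longer chain such as ethoxy follows methoxy or methyl. Also open, as far as these compounds go, is whether the same contrast between the two cores appears in other cell lines.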